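This account rests on a few compounds, and the source may have more. Where it says the series, first, only, none or still open, it means among the compounds named here.

Measured so far:
- compound 1 `COc1ccc(S(=O)(=O)N2CCc3cccc(NS(=O)(=O)c4ccc(F)cc4)c32)cc1`: 1200 nM
- compound 2 `COc1ccc(S(=O)(=O)N2CCc3cc(Br)cc(NC(=O)c4ccco4)c32)cc1`: 89 nM

Both numbers come from a functional assay on KB cells (Homo sapiens) for cytotoxicity; a higher number here means a weaker inhibitor, a lower number a stronger inhibitor. Compound 1, at 1200 nM, has the higher of the two numbers and so is the weaker inhibitor. Compound 2, at 89 nM, sits lower by a gap well beyond the usual scatter of repeated measurements.

The next compound to be tested is compound 3 `COc1ccc(S(=O)(=O)N2CCc3cccc(NCc4ccccc4)c32)cc1`. It keeps the core of compound 1 and changes one place: benzyl in place of (4-fluorophenyl)sulfonyl on a nitrogen on an aromatic ring.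

For the measured compounds named here, no measured pair shows what a change at this place does, since compound 1 and compound 2 differ in more than one place. The best anchor is therefore compound 1 itself, at 1200 nM. The expected change, a 1.3-fold higher number from compound 1 to compound 3 (0.10 log units; within the scatter), is no larger than the scatter and has no firm direction, although a real move either way remains possible. The estimate for compound 3 is 1500 nM, with an expected range from 250 nM to 8000 nM.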

Compound 3, half-maximal inhibitory concentration: > 10000 nM
Compound 3: a limit, no number; the forecaster's own chance of this, stated with the estimate: 15%; middle value at least 6.6-fold (0.82 log units) from the limit.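

In this assay compound 3 gives > 10000 nM, which is a limit of the assay and not a number. Even so, this reading gives the first view of a single change at the nitrogen on the aromatic ring, something the first two compounds could not offer: putting benzyl in place of (4-fluorophenyl)sulfonyl gives an at least 8.3-fold higher number from compound 1 to compound 3 (0.92 log units; beyond the scatter), so within this pair the group on that nitrogen clearly matters for the cytotoxicity read-out. The size of this step is only a lower bound, and it rests on a single pair and on this reading: the limit of > 10000 nM in this assay, at which 1 of the 3 values shown sits.

The swap changes several things at once, as benzyl has a carbon link to the nitrogen where (4-fluorophenyl)sulfonyl has a sulfonyl, and it also has no fluorine, so this one step cannot say which of these differences counts. Going by these compounds, what a free amine, a methylsulfonyl group or a phenylsulfonyl group without the fluorine would do on this nitrogen stays open, and these would help to separate the sulfonyl link from the ring it carries.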